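Benzyl Substitution Carried Over to a Second Amidine Core

The source may hold more compounds than are shown below. What is called first, only, known or untested is meant among the compounds shown, and "the series" means these compounds.

In a functional assay on MDA-MB-231 cells (Homo sapiens) for cytotoxicity, read by MTT assay, with a stated time of 72 h (a lower number here means a stronger inhibitor, a higher number a weaker inhibitor), compound 2 `CN1CCN(c2ccc(NC(=N)c3cc4cn(C)nc4cn3)cc2)CC1` gives 20500 nM. Compound 1 `COc1ccc(Cn2cc3cc(C(=N)Nc4ccc(N5CCN(C)CC5)cc4)ncc3n2)cc1` carries 4-methoxyphenyl in place of hydrogen on a saturated chain carbon bound to an aromatic nitrogen and gives 8000 nM in this assay, a step of a 2.6-fold lower number from compound 2 to compound 1 (0.41 log units; beyond the scatter). Compound 3 `CN1CCN(c2ccc(NC(=N)c3cc4c(-c5ccccc5)nn(C)c4cn3)cc2)CC1` is built on a different core; how the two cores differ is not broken down here. In this assay compound 3 gives 4900 nM, which lies within the scatter of the number for compound 1 and beyond the scatter relative to compound 2.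

Compound 4 `COc1ccc(Cn2nc(-c3ccccc3)c3cc(C(=N)Nc4ccc(N5CCN(C)CC5)cc4)ncc32)cc1` has not yet been measured. It differs from compound 3 by 4-methoxyphenyl in place of hydrogen on a saturated chain carbon bound to an aromatic nitrogen, the same change that separates compound 1 from compound 2, made at the same place. Within the data shown here, the only precedent for this change is the step of a 2.6-fold lower number from compound 2 to compound 1 (0.41 log units; beyond the scatter), and the expectation for compound 4 rests on that single case. A step of about a 2.5-fold lower number from compound 3 to compound 4 (0.39 log units; beyond the scatter) is expected in this assay. Compound 4 is therefore estimated to give about 2000 nM, with a likely range from 800 nM to 6000 nM.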

Compound 4, half-maximal inhibitory concentration: 1760 nM
Compound 4: the middle estimate sits 1.1-fold (0.06 log units) above what was measured, and the stated range covers the measured number.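

In this assay, the change from methyl to 4-methoxybenzyl gives a 2.8-fold lower number from compound 3 to compound 4 (0.44 log units; beyond the scatter). Set beside the earlier case, the change carries over from one core to the other with a step of matching size: the same change on two cores in this assay, a 2.6-fold lower number (0.41 log units; beyond the scatter) from compound 2 to compound 1 and a 2.8-fold lower number (0.44 log units; beyond the scatter) from compound 3 to compound 4, 1.1-fold (0.04 log units) apart, within the scatter of two such steps. This shows that the lowering held on these two cores in this one cell assay, but two cases do not make a rule for the whole series, and they cannot tell which part of the 4-methoxybenzyl group accounts for the step or whether it would appear in other cells.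

The compounds shown leave open whether plain benzyl, 4-chlorobenzyl or a longer chain such as phenethyl would give a step of similar size in the same place. From the compounds shown here alone, it also remains open how an amine or a carboxylic acid carried on that chain would behave on either core.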